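Furan to Pyridine: Expected Solubility of Compound 3

A few compounds are considered here, and "the series" means these few. Any claim that something is new, unique, unknown or untested is made for them only; others in the source may bear on it.

Within the data shown here, compound 2 `Cc1cc(NCc2ccccn2)n2ncc(-c3ccco3)c2n1` is the only compound with a number in a physicochemical assay for solubility, read by HPLC, using the shake flask method, measured as kinetic solubility, with a stated time of 2 h, at pH 7.4 (a higher number here means a more soluble compound, a lower number a less soluble compound), where compound 2 gives 48800 nM. Compound 1 `Cc1cc(NCc2ccccn2)n2ncc(-c3ccc(F)cc3)c2n1` reaches only a limit in this assay, < 5000 nM. Among the measured compounds shown here, the single measured step, an at least 9.7-fold higher number from compound 1 to compound 2 (0.98 log units; beyond the scatter), put furan-2-yl in place of 4-fluorophenyl, and compound 1 sits at the limit of < 5000 nM in this assay, at which 1 of the 2 values shown sits. Compound 3 `Cc1cc(NCc2ccccn2)n2ncc(-c3ccncc3)c2n1` differs from compound 2 by pyridin-4-yl in place of furan-2-yl on an aromatic carbon. This change does not match the measured step, so for compound 3 only a small shift is expected, a 1.6-fold higher number from compound 2 to compound 3 (0.21 log units; within the scatter), within the usual scatter. The estimate for compound 3 is 80000 nM, between 25000 nM and 250000 nM.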

Compound 3, solubility: 161000 nM
The estimate for compound 3 lay 2.0-fold (0.30 log units) below the measured number, within the range that was stated.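

In this assay, exchanging one aromatic ring with a single hetero atom for another at this position still shifts the read-out beyond the scatter: pyridin-4-yl in place of furan-2-yl gives a 3.3-fold higher number from compound 2 to compound 3 (0.52 log units; beyond the scatter). Pyridin-4-yl in place of 4-fluorophenyl gives an at least 32-fold higher number from compound 1 to compound 3 (1.50 log units; beyond the scatter). The figure for compound 1 is a limit, not a number: the limit of < 5000 nM in this assay, at which 1 of the 3 values shown sits.

From the compounds shown here alone, what remains open is whether the nitrogen of pyridin-4-yl accounts for these steps. Plain phenyl or pyridin-3-yl at this place would test that, and an added amine on the pyridine would show whether the number can go further.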